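The source may hold more compounds than are shown below. What is called first, only, known or untested is meant among the compounds shown, and "the series" means these compounds.

Measured so far:

- compound 1, `Cc1nn(C)cc1C(=O)Nc1cncc(-c2cc(Cl)cc(Cl)c2)c1N1CCC(N)CC1`: in a functional assay on CHO-K1 cells for agonist activity at somatostatin receptor type 2 (Homo sapiens), read by cAMP accumulation, with a stated time of 30 min (a lower number here means that less compound is needed, a higher number that more compound is needed for the effect), compound 1 gives 0.12 nM
- compound 2, `Cc1cc(C)cc(C(=O)Nc2cncc(-c3cc(C)cc(C)c3)c2N2CCC(N)CC2)c1`: compound 2 gives 0.04 nM
- compound 3, `Cc1cc(C)cc(-c2cncc(-c3nc4cc(F)ccc4[nH]3)c2N2CCC(N)CC2)c1`: compound 3 gives 0.013 nM

Compound 1 stands at the highest number of the three. Compound 2 sits below it by a margin beyond the scatter, and compound 3 lies further below still, also beyond the scatter. Among the measured compounds shown here, compounds 2 and 3 carry different groups at more than one place relative to compound 1, so no single structural step between measured compounds can be read off here; the values show only that both of them need less compound than compound 1 for the effect.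

The next compound is compound 4, `Cc1cc(C(=O)Nc2cncc(-c3cc(Cl)cc(Cl)c3)c2N2CCC(N)CC2)n(C)n1`. It keeps every atom of compound 1, joined differently: 1,3-dimethyl-1H-pyrazol-5-yl in place of 1,3-dimethyl-1H-pyrazol-4-yl on a carbonyl carbon. The amide, the shared core and the basic ring are untouched.

For the measured compounds named here, no measured pair shows what moving the carbonyl from one ring position of the same pyrazole to another does, so no direction is backed by data. The expectation is a step of modest size, with the number for compound 4 most likely close to that of compound 1 and, if anything, somewhat higher: a 1.7-fold higher number from compound 1 to compound 4 (0.22 log units; within the scatter). Compound 4 is estimated at 0.2 nM, with a range from 0.06 nM to 0.7 nM.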

Compound 4, half-maximal effective concentration: 0.041 nM
Estimate against measurement, compound 4: 4.9-fold (0.69 log units) above, outside the stated range (below it).
By their numbers in this assay, from the lowest: compound 3; then compounds 2 and 4 (each within the scatter of the next); then compound 1.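

Within the pyrazole amide, the attachment point of the ring alone is enough to move the result in this assay: 1,3-dimethyl-1H-pyrazol-5-yl in place of 1,3-dimethyl-1H-pyrazol-4-yl on a carbonyl carbon gives a 2.9-fold lower number from compound 1 to compound 4 (0.47 log units; beyond the scatter), a modest step but beyond the scatter. Among the compounds shown here, this is the first pair that differs in one place, and it shows that this position responds to a change that leaves the heavy-atom count and the counts of hydrogen-bond donors and acceptors of the group as they were. Nothing available on these compounds accounts for the step, so it stands as an observation about this one pair.

Still open, as far as these compounds go, is how the same carbonyl carbon responds to other groups, such as an unsubstituted pyrazole, a 1-methylimidazole or a saturated ring such as morpholine, and whether the order of the two pyrazole isomers is particular to these two methyl groups. Also open, from the compounds shown here alone, is whether the same exchange gives a step of similar size and direction when the rest of the molecule differs from compound 1, as a single pair cannot establish a trend across the series.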